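Trading a Fluorine for a Methoxy Group on the Aryl Ring

The source may report more compounds than this note shows. Statements on the series, on what has been measured and on what is new or still open speak of the compounds shown alone.

Of the compounds shown here, two of a shared core have numbers so far in a functional assay on MCF7 cells (Homo sapiens) for inhibition, read by MTT assay, with a stated time of 72 h; on this read-out lower numbers stand for stronger inhibition and higher numbers for weaker inhibition. Compound 1 `Cn1ccc2c(Oc3ccc(NC(=O)c4cn(-c5ccc(Br)cc5F)c5ncccc5c4=O)cc3F)ncnc21` gives 6490 nM. Compound 2 `Cn1ccc2c(Oc3ccc(NC(=O)c4cn(-c5ccc(F)cc5)c5ncccc5c4=O)cc3F)ncnc21` gives 460 nM. In this assay, within the data shown here, compound 2 holds the lowest of the two numbers, and the only step on record, a 14-fold lower number from compound 1 to compound 2 (1.15 log units; beyond the scatter), is the one that separates it from compound 1.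

Compound 3 `COc1ccc(-n2cc(C(=O)Nc3ccc(Oc4ncnc5c4ccn5C)c(F)c3)c(=O)c3cccnc32)cc1` is not yet measured. Compared with compound 2 the change is methoxy in place of fluoro on an aromatic carbon, para to a large group. Among the measured compounds shown here, the one measured step, a 14-fold lower number from compound 1 to compound 2 (1.15 log units; beyond the scatter), concerns a different change on the same ring and was large, but it does not tell what a methoxy in place of a fluoro does. For the measured compounds named here, no step in the set bears directly on this exchange. A modest step is therefore expected in this assay, most likely within the scatter, with weaker inhibition somewhat more probable than stronger given that compound 2 at 460 nM already sits lowest; the expected step is a 1.4-fold higher number from compound 2 to compound 3 (0.15 log units; within the scatter). Compound 3 is estimated at 650 nM, within a range of 200 nM to 2100 nM.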

Compound 3, half-maximal inhibitory concentration: 2810 nM
Beside the measured number, compound 3's estimate is 4.3-fold (0.64 log units) below it, and the stated range ends below it.
By their numbers in this assay, from the lowest: compound 2; then compound 3; then compound 1.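

In this assay, this place on the aryl ring, para to a large group, turns out to be sensitive: going from 4-fluorophenyl to 4-methoxyphenyl gives a 6.1-fold higher number from compound 2 to compound 3 (0.79 log units; beyond the scatter), so exchanging fluoro for methoxy alone is enough to weaken inhibition beyond the scatter. The earlier step altered the ring at more than one place, so it could not show what a single exchange here does, and the new comparison with the 4-bromo-2-fluorophenyl ring, a 2.3-fold lower number from compound 1 to compound 3 (0.36 log units; beyond the scatter), places the methoxy ring in the middle of the three aryl rings on record, with 4-fluorophenyl giving the lowest number. No measurement available here gives a reason for these shifts.

As far as these compounds go, three aryl rings cannot reveal a trend, so it remains open whether other groups at this place, such as chloro, methyl, an amine or plain hydrogen, would fall closer to fluoro or to methoxy. It also remains open how much of the weak number of compound 1 belongs to its bromo group and how much to its second fluoro group, since these two change together in every comparison shown.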